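The source may report more compounds than this note shows. Statements on the series, on what has been measured and on what is new or still open speak of the compounds shown alone.

Among the measured compounds shown here, in a functional assay on B16-F10 cells (Mus musculus) for antiproliferative activity, read by MTT assay, with a stated time of 48 h (on this read-out higher numbers stand for weaker inhibition and lower numbers for stronger inhibition), compound 1 `CC(=O)N1N=C(c2ccc(F)cc2)CC1c1ccc2c(c1)OCCO2` gives 53100 nM and compound 2 `CC(=O)N1N=C(c2ccc(Cl)cc2)CC1c1ccc2c(c1)OCCO2` gives 47300 nM on the shared core, so compound 2 sits within the scatter of the only other number available. Compound 3 `COc1ccc(C2=NN(C(C)=O)C(c3ccc4c(c3)OCCO4)C2)cc1` has methoxy in place of chloro on an aromatic carbon, para to a large group (methoxy in place of chloro on an aromatic carbon), and the core is unchanged. For the measured compounds named here, the one measured step that bears on this place is a 1.1-fold lower number from compound 1 to compound 2 (0.05 log units; within the scatter) and it lies within the scatter. Going by the values given here, that step swaps one halogen for another, and no measured compound carries methoxy, so the data give no size for this change. No step beyond the scatter is therefore expected in this assay in either direction. The expected step is a 1.1-fold lower number from compound 2 to compound 3 (0.02 log units; within the scatter) at this stage. For compound 3 the estimated value is 45000 nM with an expected range from 20000 nM to 95000 nM for repeat measurements.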

Compound 3, half-maximal inhibitory concentration: 31700 nM
Estimate against measurement, compound 3: 1.4-fold (0.15 log units) above, within the range that was stated.
By their numbers in this assay, from the lowest: compounds 3, 2 and 1 (each within the scatter of the next).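

In this assay, among the compounds shown here, methoxy is the first group at this place that is not a halogen, on an aromatic carbon para to a large group: a 1.5-fold lower number from compound 2 to compound 3 (0.17 log units; within the scatter) goes with chloro leaving, and a 1.7-fold lower number from compound 1 to compound 3 (0.22 log units; within the scatter) goes with fluoro leaving. Moving from halogen to methoxy, which brings a hydrogen-bond acceptor where chloro counts none, therefore stays within the scatter against both halogens, and 4-methoxyphenyl does not separate from 4-chlorophenyl at this stage. No measurement at hand gives a reason for the size of these steps.

As far as these compounds go, whether any group at this place can produce a step beyond the scatter stays open; an amine, a carboxylic acid or a longer chain such as butoxy would put that to the test. From the compounds shown here alone, what changes elsewhere on the shared core would do also stays open.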